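A Sulfanyl Group Replaces Chloro on the Shared Core

A few compounds are considered here, and "the series" means these few. Any claim that something is new, unique, unknown or untested is made for them only; others in the source may bear on it.

Compound 3 `Cc1nc2c3ccccc3ccc2c2nc3c(ccc4ccccc43)c(-c3ccccc3Cl)c12` gives 52500 nM in a functional assay on AGS cells (Homo sapiens) for cytotoxicity, read by MTT assay, with a stated time of 48 h (a higher number here means a weaker inhibitor, a lower number a stronger inhibitor), the second highest of three numbers. Compound 1 `COc1ccc(-c2c3ccc4ccccc4c3nc3c2c(C)nc2c4ccccc4ccc32)cc1` gives 66400 nM, and the step of a 1.3-fold lower number from compound 1 to compound 3 (0.10 log units; within the scatter) lies within the scatter. Compound 2 `Cc1nc2c3ccccc3ccc2c2nc3c(ccc4ccccc43)c(-c3ccccc3N)c12` gives 12100 nM; the step of a 4.3-fold higher number from compound 2 to compound 3 (0.64 log units; beyond the scatter) is the one that bears most on the change now considered, and the step of a 5.5-fold lower number from compound 1 to compound 2 (0.74 log units; beyond the scatter) points the same way. Compound 4 `Cc1nc2c3ccccc3ccc2c2nc3c(ccc4ccccc43)c(-c3ccccc3S)c12` carries the change (sulfanyl in place of chloro on an aromatic carbon), so the chloro group of compound 3 gives way to a group that, like the amino group of compound 2, can donate and accept a hydrogen bond. A modest lowering is therefore expected, a 2.1-fold lower number from compound 3 to compound 4 (0.32 log units; beyond the scatter), because a 4.3-fold higher number from compound 2 to compound 3 (0.64 log units; beyond the scatter) showed chloro weaker than amino. Compound 4 is estimated at 25000 nM, within 10000 nM to 70000 nM.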

Compound 4, half-maximal inhibitory concentration: 4070 nM
For compound 4 the middle estimate is 6.1-fold (0.79 log units) above the measured one; the measured number lies below the stated range.
By their numbers in this assay, from the lowest: compound 4; then compound 2; then compounds 3 and 1 (each within the scatter of the next).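

In this assay the change from chloro to sulfanyl brings a 13-fold lower number from compound 3 to compound 4 (1.11 log units; beyond the scatter) and shows that this position responds strongly to the group it carries. Sulfanyl and amino can both donate a hydrogen bond, yet they are not interchangeable here: there is a 3.0-fold lower number from compound 2 to compound 4 (0.47 log units; beyond the scatter) between them. Against 4-methoxyphenyl, the 2-sulfanylphenyl group gives a 16-fold lower number from compound 1 to compound 4 (1.21 log units; beyond the scatter) and leaves compound 4 with the lowest number of the four.

From the compounds shown here alone, whether a hydroxyl, methylthio or carboxylic acid group here would match sulfanyl remains open. No measurement available explains the size of these steps.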